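The source may hold more compounds than are shown below. What is called first, only, known or untested is meant among the compounds shown, and "the series" means these compounds.

Compound 1 `O=C(NC1CCCCC1)c1ccc(C#Cc2ccccc2)nc1` gives 240 nM in a functional assay on BHK cells for positive allosteric modulation of metabotropic glutamate receptor 5 (Homo sapiens), read by FLIPR and calcium flux; a higher number here means that more compound is needed for the effect, a lower number that less compound is needed.
Compound 2 `O=C(NCc1ccco1)c1ccc(C#Cc2ccccc2)nc1` gives 180 nM in this assay.
Compound 3 `O=C(NCc1ccsc1)c1ccc(C#Cc2ccccc2)nc1` gives 140 nM in this assay.

Compound 3 shows the lowest of the three numbers, yet its gap to compound 2 and to compound 1 is within the scatter, so the three stand level. Compound 4 `O=C(c1ccc(C#Cc2ccccc2)nc1)N1CCOCC1` differs from compound 3 by morpholin-4-yl in place of ((thiophen-3-yl)methyl)amino on a carbonyl carbon. The measured steps, a 1.3-fold lower number from compound 1 to compound 2 (0.12 log units; within the scatter), a 1.7-fold lower number from compound 1 to compound 3 (0.23 log units; within the scatter) and a 1.3-fold lower number from compound 2 to compound 3 (0.11 log units; within the scatter), each exchange one group for another on the amide nitrogen and all stay within the scatter; none removes the amide hydrogen, so they bear only loosely on this change. Compound 4 is therefore expected to give about 450 nM, plausibly between 150 nM and 1500 nM, an estimated step of a 3.2-fold higher number from compound 3 to compound 4 (0.51 log units; beyond the scatter).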

Compound 4, half-maximal effective concentration: 990 nM
For compound 4 the middle estimate is 2.2-fold (0.34 log units) below the measured one, and the stated range covers the measured number.
By their numbers in this assay, from the lowest: compounds 3, 2 and 1 (each within the scatter of the next); then compound 4.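

Morpholin-4-yl on the carbonyl carbon gives a 7.1-fold higher number from compound 3 to compound 4 (0.85 log units; beyond the scatter) and a 5.5-fold higher number from compound 2 to compound 4 (0.74 log units; beyond the scatter) and also a 4.1-fold higher number from compound 1 to compound 4 (0.62 log units; beyond the scatter) in this small set. This is the only change shown that removes the amide hydrogen, and the only one that moves the number beyond the scatter. Nothing shown gives a cause for this rise.

On these data alone, it stays open whether the missing amide hydrogen or the morpholine ring matters more. A methyl group on the amide nitrogen of compound 3, or a piperidin-1-yl group on the carbonyl carbon, would help separate the two.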